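The source may hold more compounds than are shown below. What is called first, only, known or untested is meant among the compounds shown, and "the series" means these compounds.

Measured in a functional assay on SK-MEL-2 cells (Homo sapiens) for inhibition, read by sulforhodamine B assay, with a stated time of 48 h; a higher number here means a weaker inhibitor of growth, a lower number a stronger inhibitor of growth:
- Compound 1 `O=C(Cc1csc2nc(-c3ccc(Br)cc3)cn12)N/N=C/c1ccccc1O`: 53700 nM
- Compound 2 `O=C(Cc1csc2nc(-c3ccc(Br)cc3)cn12)N/N=C/c1ccc(O)cc1`: 95500 nM

In this assay, among the measured compounds shown here, compound 2 gives 95500 nM, and the only measured step, a 1.8-fold higher number from compound 1 to compound 2 (0.25 log units; within the scatter), leaves it level with the one other measured compound. Compound 3 `O=C(Cc1csc2nc(-c3ccc(Br)cc3)cn12)N/N=C/c1ccc(Cl)cc1Cl` carries a larger change: 2,4-dichlorophenyl in place of 4-hydroxyphenyl on a carbon with a double bond to nitrogen. For the measured compounds named here, no measured compound shows what happens when 2,4-dichlorophenyl enters, so a 1.8-fold higher number from compound 1 to compound 2 (0.25 log units; within the scatter) is only a weak guide, and it stays within the scatter. No clear shift is therefore expected, and the estimated step, a 1.6-fold lower number from compound 2 to compound 3 (0.20 log units; within the scatter), stays within the scatter too. The expected value for compound 3 is 60000 nM, with an estimated range of 20000 nM to 100000 nM.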

Compound 3, concentration for total growth inhibition: > 100000 nM
Compound 3: no number, only a limit; the forecaster's own chance of this, stated with the estimate: 15%; middle value at least 1.6-fold (0.22 log units) from the limit.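

In this assay compound 3 gives no number, only a limit of the assay: the limit of > 100000 nM in this assay, at which 1 of the 3 values shown sits. The steps to it are therefore floors: an at least 1.0-fold higher number from compound 2 to compound 3 (0.01 log units; that floor lies within the scatter), and an at least 1.8-fold higher number from compound 1 to compound 3 (0.27 log units; that floor lies within the scatter). So at this carbon with a double bond to nitrogen, 2,4-dichlorophenyl, with 0 hydrogen-bond donors, brings no lower number than either hydroxyphenyl group, though the true size of the change cannot be read. Still open, from the compounds shown here alone, is how far compound 3 lies past its limit, and what a phenyl ring carrying an amine or a carboxylic acid would give in this place.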